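Replacing a cyclohexyl ether with a bromo-anilino group

The compounds below may be only part of what the source reports. "The series", "measured", "known", "first", "only" and "open" are said of these compounds alone.

Three compounds have been measured:
Compound 1, `CCCCOC1=C(C(=O)c2ccccc2)C(c2ccc(Br)cc2)N(CCCn2ccnc2)C1=O`: in a functional assay on SAOS-2 cells (Homo sapiens) for antiproliferative activity, read by MTT assay, with a stated time of 72 h (on this read-out lower numbers stand for stronger inhibition and higher numbers for weaker inhibition), compound 1 gives 11600 nM.
Compound 2, `O=C(C1=C(OC2CCCCC2)C(=O)N(CCCn2ccnc2)C1c1ccc(Br)cc1)c1ccccc1`: compound 2 gives 29700 nM.
Compound 3, `O=C(C1=C(Nc2ccc(Cl)cc2)C(=O)N(CCCn2ccnc2)C1c1ccc(Br)cc1)c1ccccc1`: compound 3 gives 24800 nM.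

Compound 2 has the highest number of the three. The step of a 2.6-fold higher number from compound 1 to compound 2 (0.41 log units; beyond the scatter) stands beyond the scatter, whereas its gap to compound 3 is a 1.2-fold lower number from compound 2 to compound 3 (0.08 log units; within the scatter), which stays within it, so compound 2 and compound 3 cannot be told apart on these numbers.

Compound 4, `O=C(C1=C(Nc2cccc(Br)c2)C(=O)N(CCCn2ccnc2)C1c1ccc(Br)cc1)c1ccccc1`, differs from compound 2 in one place: (3-bromophenyl)amino in place of cyclohexyloxy on a double-bonded ring carbon

The step that bears most directly on this change is a 1.2-fold lower number from compound 2 to compound 3 (0.08 log units; within the scatter), since it also swaps cyclohexyloxy for an arylamino group at the same ring carbon, and it fell within the scatter. The related step of a 2.1-fold higher number from compound 1 to compound 3 (0.33 log units; beyond the scatter) was modest. Among the compounds with values here, a bromine on the ring instead of a chlorine, and sitting at a different ring position, is the only remaining difference, and there is no measured step covering that. The expectation is therefore a step of a 1.2-fold lower number from compound 2 to compound 4 (0.07 log units; within the scatter), close to no change beyond the scatter. Compound 4 is estimated at 25000 nM, with a range from 10000 nM to 60000 nM.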

Compound 4, half-maximal inhibitory concentration: 9090 nM
Beside the measured number, compound 4's estimate is 2.8-fold (0.44 log units) above it, outside the stated range (below it).
By their numbers in this assay, from the lowest: compounds 4 and 1 (each within the scatter of the next); then compounds 3 and 2 (each within the scatter of the next).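

In this assay, the step (a 3.3-fold lower number from compound 2 to compound 4 (0.51 log units; beyond the scatter)) shows that an arylamino group at this double-bonded ring carbon can give stronger inhibition than cyclohexyloxy, something the (4-chlorophenyl)amino group of compound 3 did not show. The aryl ring itself therefore counts, as the direct comparison of the two arylamino groups confirms (a 2.7-fold lower number from compound 3 to compound 4 (0.44 log units; beyond the scatter)), and exchanging 4-chlorophenyl for 3-bromophenyl on the amine nitrogen is enough to produce a step beyond the usual scatter. The (3-bromophenyl)amino group and the butoxy group cannot be told apart on their numbers (a 1.3-fold lower number from compound 1 to compound 4 (0.11 log units; within the scatter)), and nothing available here explains why the aryl exchange changes the result.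

That exchange alters both the halogen and its place on the ring, so the compounds shown cannot say which of the two matters; a (3-chlorophenyl)amino or (4-bromophenyl)amino group at this carbon would separate them. A plain phenylamino group would show whether any halogen is needed at all, and whether the lower number of compound 4 depends on the bromine.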